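The source may report more compounds than this note shows. Statements on the series, on what has been measured and on what is new or still open speak of the compounds shown alone.

Measured compounds:
- compound 1, `CC[C@@H](Nc1c(Nc2cccc(C(=O)N(C)C)c2O)c(=O)c1=O)c1sccc1C`: in an assay on CHO cells for displacement of a labelled ligand from C-X-C chemokine receptor type 1 (Homo sapiens) (a lower number here means a stronger inhibitor, a higher number a weaker inhibitor), compound 1 gives 123 nM
- compound 2, `CCc1ccoc1[C@@H](CC)Nc1c(Nc2cccc(C(=O)N(C)C)c2O)c(=O)c1=O`: in this assay compound 2 gives 379 nM
- compound 3, `CC[C@@H](Nc1c(Nc2cccc(C(=O)N(C)C)c2O)c(=O)c1=O)c1cc(C(C)C)co1`: in this assay compound 3 gives 3 nM

Compound 3 holds the lowest number of the three; the nearest is compound 1, with a 41-fold lower number from compound 1 to compound 3 (1.61 log units; beyond the scatter), and the furthest is compound 2, with a 130-fold lower number from compound 2 to compound 3 (2.10 log units; beyond the scatter). Both of those steps change the whole aromatic group on the saturated chain carbon bound to the nitrogen, and together they show that the group on that carbon can move the number a great deal. Compound 1 and compound 2 differ by a 3.1-fold higher number from compound 1 to compound 2 (0.49 log units; beyond the scatter).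

Compound 4, `CCC(C)c1coc([C@@H](CC)Nc2c(Nc3cccc(C(=O)N(C)C)c3O)c(=O)c2=O)c1`, keeps the shared core and the furan and differs from compound 3 only by methyl in place of hydrogen on a saturated chain carbon, two bonds along the chain from an aromatic carbon. Going by the values given here, no measured step touches this part of the molecule, so the large steps already seen give no direct guide; the change is small and stays on the same furan. Compound 4 is therefore expected to stay close to compound 3, with a 1.7-fold higher number from compound 3 to compound 4 (0.22 log units; within the scatter) as the estimated step. In this assay compound 4 is estimated at 5 nM, with a range from 1.5 nM to 15 nM.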

Compound 4, inhibition constant: 7.6 nM
Compound 4: middle estimate off by 1.5-fold (0.18 log units), on the low side, and the stated range covers the measured number.
By their numbers in this assay, from the lowest: compound 3; then compound 4; then compound 1; then compound 2.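

Going from isopropyl to sec-butyl on the furan gives a 2.5-fold higher number from compound 3 to compound 4 (0.40 log units; beyond the scatter) in this assay, so this saturated chain carbon, two bonds along the chain from an aromatic carbon, does respond to one added methyl, though only modestly. The large advantage is not unique to 4-isopropylfuran-2-yl, since 4-(sec-butyl)furan-2-yl also keeps it, with a 50-fold lower number from compound 2 to compound 4 (1.70 log units; beyond the scatter) and a 16-fold lower number from compound 1 to compound 4 (1.21 log units; beyond the scatter) in the same assay. No available evidence bears on what lies behind these steps.

The compounds shown leave open how a longer chain such as pentyl would fare at this place on the furan. They also leave open whether an amine or a carboxylic acid at the end of that chain would keep the number close to that of compound 4.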